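Swapping cyclohexyl for 4-nitrophenyl on compound 1

This account rests on a few compounds, and the source may have more. Where it says the series, first, only, none or still open, it means among the compounds named here.

Compound 1 `C/C=C1/[C@H](O[C@@H]2O[C@H](CO)[C@@H](O)[C@H](O)[C@H]2O)OC=C(C(=O)OC)[C@H]1CC(=O)OCCC1CCCCC1`: 2000 nM
Compound 2 `C/C=C1/[C@H](O[C@@H]2O[C@H](COC(C)=O)[C@@H](OC(C)=O)[C@H](OC(C)=O)[C@H]2OC(C)=O)OC=C(C(=O)OC)[C@H]1CC(=O)SCCC`: > 15000 nM (a limit)
Compound 3 `C/C=C1/[C@H](O[C@@H]2O[C@H](COC(C)=O)[C@@H](OC(C)=O)[C@H](OC(C)=O)[C@H]2OC(C)=O)OC=C(C(=O)OC)[C@H]1CC(=O)OCC`: > 15000 nM (a limit)

Among the compounds with values here, in a functional assay on SK-BR-3 cells (Homo sapiens) for antiproliferative activity, read by MTT assay, with a stated time of 72 h (on this read-out higher numbers stand for weaker inhibition and lower numbers for stronger inhibition), compound 1 gives 2000 nM, the only true number among the three. The other two results are limits, not numbers: the limit of > 15000 nM in this assay, at which 2 of the 3 values shown sit. Compound 4 `C/C=C1/[C@H](O[C@@H]2O[C@H](CO)[C@@H](O)[C@H](O)[C@H]2O)OC=C(C(=O)OC)[C@H]1CC(=O)OCCc1ccc([N+](=O)[O-])cc1` keeps the core of compound 1 and differs as follows: 4-nitrophenyl in place of cyclohexyl on a saturated chain carbon, two bonds along the chain from an oxygen next to a carbonyl group. In words, 4-nitrophenyl stands in place of cyclohexyl on a saturated chain carbon. Within the data shown here, the sole measured step, a step that the two limits leave unreadable from compound 2 to compound 3, is a different change, so it gives no size for this one. With only compound 1 at 2000 nM as a guide, no shift beyond the scatter is expected, and the expected step is a 1.3-fold higher number from compound 1 to compound 4 (0.10 log units; within the scatter). Compound 4 is estimated at 2500 nM, within an expected range of 700 nM to 10000 nM.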

Compound 4, half-maximal inhibitory concentration: > 20000 nM
Compound 4: a limit, no number; the forecaster's own chance of this, stated with the estimate: 15%; middle value at least 8.0-fold (0.90 log units) from the limit.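

In this assay, putting 4-nitrophenyl in place of cyclohexyl gives an at least 10-fold higher number from compound 1 to compound 4 (1.00 log units; beyond the scatter), the first readable step among the compounds shown. It shows that the group at the end of this chain is not free to change without cost to the read-out. The result for compound 4 is a limit, not a number: the limit of > 20000 nM in this assay, at which 1 of the 4 values shown sits.

The compounds shown leave open whether the aromatic ring or its nitro group carries this loss, and an unsubstituted phenyl in the same place would separate the two. On these data alone, whether a smaller ring such as cyclopentyl is tolerated here also stays open.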